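Adding a second methoxy group to a chloro-bearing series

A few compounds are considered here, and "the series" means these few. Any claim that something is new, unique, unknown or untested is made for them only; others in the source may bear on it.

The shared core is a small sulfur-containing ring linked to a thiophene that carries a substituted phenyl ring. Compound 1 `COc1ccc(-c2cc(/N=C3\SCC(=O)N3c3cccc(OC)c3)cs2)cc1` carries a methoxy group on that phenyl ring; in a functional assay on HCT-116 cells (Homo sapiens) for cytotoxicity, read by MTT assay, with a stated time of 72 h (a lower number here means a stronger inhibitor, a higher number a weaker inhibitor), compound 1 gives 2700 nM. Compound 2 `COc1cccc(N2C(=O)CS/C2=N\c2csc(-c3ccc(Cl)cc3)c2)c1` carries a chloro in its place. For compound 2 this assay returned only a limit, > 50000 nM, with no single number. Compound 3 `O=C1CS/C(=N\c2csc(-c3ccc(Cl)cc3)c2)N1c1ccccc1` has no result in this assay, "not determined" (no result reported). For the measured compounds named here, the single measured step, an at least 18-fold higher number from compound 1 to compound 2 (1.26 log units; beyond the scatter), is large, and it leaves compound 2 sitting at the limit of > 50000 nM in this assay, at which 1 of the 3 values shown sits. Compound 4 `COc1ccc(N2C(=O)CS/C2=N\c2csc(-c3ccc(Cl)cc3)c2)cc1OC` differs from compound 2 by methoxy in place of hydrogen on an aromatic carbon. Going by the values given here, no measured step tests this kind of change, so the only guide is the weak standing of compound 2. The expected step of an at least 1.2-fold lower number from compound 2 to compound 4 (0.09 log units; that floor lies within the scatter) is therefore small and uncertain, and the chance of another limit is high. Compound 4 is estimated at 40000 nM, expected between 8000 nM and 150000 nM.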

Compound 4, half-maximal inhibitory concentration: 49800 nM
Estimate against measurement, compound 4: 1.2-fold (0.10 log units) below, and the stated range covers the measured number.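

Methoxy in place of hydrogen at this position, ortho to a methoxy group and para to a large group, yields a compound with a single measured number: in this assay compound 4 gives 49800 nM. For the compounds shown here, the only reading of the change is a number no higher from compound 2 to compound 4 (the limit leaves the size open), so the added methoxy does not raise the number, yet nothing shows that it lowers it. Its size cannot be read because compound 2 carries a limit and not a number: the limit of > 50000 nM in this assay, at which 1 of the 4 values shown sits.

The compounds shown leave open whether another group at this position, such as an amine or a carboxylic acid, would lower the number. They also leave open what the same added methoxy would do to compound 1, which has methoxy rather than chloro on its other phenyl ring.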